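Thiophene Carbonyl in Place of Isopropylsulfonyl on the Ring Nitrogen

The compounds below may be only part of what the source reports. "The series", "measured", "known", "first", "only" and "open" are said of these compounds alone.

Three compounds on a shared core have been run in an ADME assay on Caco-2 cells (Homo sapiens) for permeability, in the apical to basolateral direction; on this read-out lower numbers stand for lower permeability and higher numbers for higher permeability. Compound 1 `Cn1cncc1CN1CC(N(CC2CCN(C(=O)c3ccc(Cl)cc3)CC2)S(=O)(=O)c2ccccn2)Cc2cc(C#N)ccc21` gives 0.5 10^-6 cm/s, and compound 2 `Cn1cncc1CN1CC(N(CC2CCN(C(=O)CC(F)(F)F)CC2)S(=O)(=O)c2ccccn2)Cc2cc(C#N)ccc21` gives 0.5 10^-6 cm/s, with no change at the digits printed from compound 1 to compound 2 (within the scatter). Compound 3 `CC(C)S(=O)(=O)N1CCC(CN(C2Cc3cc(C#N)ccc3N(Cc3cncn3C)C2)S(=O)(=O)c2ccccn2)CC1` gives 0.1 10^-6 cm/s, the lowest of the three numbers, and stands a 5.0-fold lower number from compound 1 to compound 3 (0.70 log units; beyond the scatter) and a 5.0-fold lower number from compound 2 to compound 3 (0.70 log units; beyond the scatter). Compound 4 `Cn1cncc1CN1CC(N(CC2CCN(C(=O)c3cccs3)CC2)S(=O)(=O)c2ccccn2)Cc2cc(C#N)ccc21` has not yet been measured. It differs from compound 3 in one place: (thiophen-2-yl)carbonyl in place of isopropylsulfonyl on an amine nitrogen in a ring. Both earlier steps bear on this change, since compound 1 and compound 2 each carry a carbonyl group on that ring nitrogen where compound 3 carries isopropylsulfonyl, and each of those steps was a modest fall toward compound 3. The reverse direction, from compound 3 to a carbonyl-bearing analogue, is therefore expected to bring a modest rise of about the same size. Compound 4 is accordingly expected to give 0.5 10^-6 cm/s in this assay, a step of a 5.0-fold higher number from compound 3 to compound 4 (0.70 log units; beyond the scatter), with a range from 0.15 10^-6 cm/s to 1.5 10^-6 cm/s.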

Compound 4, apparent permeability: 0.5 10^-6 cm/s
Beside the measured number, compound 4's estimate shows no gap at the digits printed; the range from low to high includes it.
By their numbers in this assay, from the lowest: compound 3; then compounds 1, 2 and 4 (each within the scatter of the next).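

In this assay the step is a 5.0-fold higher number from compound 3 to compound 4 (0.70 log units; beyond the scatter) when (thiophen-2-yl)carbonyl replaces isopropylsulfonyl, the first direct rise from the sulfonyl compound to a carbonyl compound carrying a five-membered aromatic ring. Among the three carbonyl compounds, the group on the carbonyl carbon leaves the number unmoved: thiophen-2-yl in place of 2,2,2-trifluoroethyl gives no change at the digits printed from compound 2 to compound 4 (within the scatter) and thiophen-2-yl in place of 4-chlorophenyl gives no change at the digits printed from compound 1 to compound 4 (within the scatter) across these quite different groups. Nothing measured here accounts for the gap between the sulfonyl compound and the carbonyl compounds.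

Only one sulfonyl group appears among the compounds shown, so it remains open whether phenylsulfonyl on the ring nitrogen would match compound 3 or the carbonyl compounds. Also open, going by these compounds, is how a carbonyl bearing an amine, or a plain alkyl chain on that nitrogen, would read.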